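The compounds below may be only part of what the source reports. "The series", "measured", "known", "first", "only" and "open" are said of these compounds alone.

Working notes on the series.

Of the compounds shown here, three sharing the same core have been measured in an assay on membranes from Chem-1 cells for displacement of a labelled ligand from prostaglandin E2 receptor EP3 subtype (Homo sapiens), read by scintillation counting, with a stated time of 2 h; a lower number here means a stronger inhibitor, a higher number a weaker inhibitor. Compound 1 `CC(C)C(/C=C1\NC(=O)NC1=O)c1ccc(-c2ccc3cccc(F)c3c2)[nH]c1=O` gives 43 nM in this assay; compound 2 `Cc1cc(C(/C=C2\OC(=O)NC2=O)C(C)C)c(=O)[nH]c1-c1ccc2cccc(F)c2c1` gives 23 nM; compound 3 `CCC(/C=C1\OC(=O)NC1=O)(CC)c1ccc(-c2ccc3cc(F)cc(F)c3c2)[nH]c1=O` gives 28 nM. Compound 1 holds the highest of the three numbers, but its gaps to compound 3 and to compound 2 are both within the scatter of repeated measurements, so the three values are read as one level rather than as a ranking. Within the data shown here, no pair among them differs in one place only, so no single step is defined.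

Compound 4 `CC(C)C(/C=C1\SC(=O)NC1=O)c1ccc(-c2ccc3cccc(F)c3c2)[nH]c1=O` is not yet measured. It departs from compound 1 by a group of 8 heavy atoms (4 carbon, 1 nitrogen, 2 oxygen, 1 sulfur; one five-membered non-aromatic ring with 2 hetero atoms) in place of a group of 8 heavy atoms (4 carbon, 2 nitrogen, 2 oxygen; one five-membered non-aromatic ring with 2 hetero atoms), on a saturated chain carbon bound to an aromatic carbon and a saturated chain carbon. Among the measured compounds shown here, nothing among the measured compounds covers this exchange, so the direction of the step is open. The expectation for compound 4 in this assay is a step of a 1.4-fold lower number from compound 1 to compound 4 (0.16 log units; within the scatter) of no clear size beyond the scatter, with a slight lean toward a lower number. Compound 4 is accordingly estimated at 30 nM, with a range from 10 nM to 100 nM.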

Compound 4, inhibition constant: 13 nM
For compound 4 the middle estimate is 2.3-fold (0.36 log units) above the measured one, within the range that was stated.
By their numbers in this assay, from the lowest: compounds 4, 2, 3 and 1 (each within the scatter of the next, the first and the last beyond it).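

In this assay, among these compounds, the exchange on the saturated chain carbon bound to an aromatic carbon and a saturated chain carbon gives a 3.3-fold lower number from compound 1 to compound 4 (0.52 log units; beyond the scatter), the only step that can be read in one place, and it lies beyond the scatter. This position therefore does not treat the two five-membered rings alike: the count of 8 heavy atoms stays the same, while one nitrogen gives way to sulfur and the hydrogen-bond donor and acceptor counts shift. Nothing shown here bears on the reason for this step.

The oxygen-containing ring of compound 2 and compound 3 stands only on cores that differ elsewhere, leaving its place relative to the other two rings on the core of compound 1 unread. Also open, as far as these compounds go, is how this position responds to a group outside this ring type, such as a carboxylic acid.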